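The compounds below may be only part of what the source reports. "The series", "measured", "known", "first", "only" and "open" are said of these compounds alone.

Measured compounds in an ADME assay on MDCK cells (Canis lupus familiaris) for cytotoxicity, read by microscopy, with a stated time of 48 h; a lower number here means that less compound is tolerated, a higher number that more compound is tolerated:
- compound 1, `C[C@H]1[C@H](NCc2sccc2-c2ccccc2)C[C@H]2C[C@@H]1C2(C)C`: 12500 nM
- compound 2, `CCCCc1csc(CN[C@@H]2C[C@H]3C[C@@H]([C@H]2C)C3(C)C)c1`: 12500 nM
- compound 3, `Cc1n[nH]cc1CN[C@@H]1C[C@H]2C[C@@H]([C@H]1C)C2(C)C`: reported only as a limit, > 100000 nM

The value of compound 3 is a limit of this assay and not a number; (the limit of > 100000 nM in this assay, at which 1 of the 3 values shown sits). Compound 1 stands level with compound 2 at the digits shown, within the scatter of this assay, so no order between these two is claimed. Of the three values, only the limit of compound 3 sits apart from compound 1. Among the compounds with values here, no step between measured compounds that differ in one place is available in this set, so the size of a single structural change cannot yet be read from the measured values.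

Compound 4, `CCCc1ccsc1CN[C@@H]1C[C@H]2C[C@@H]([C@H]1C)C2(C)C`, remains to be measured in this assay. It differs from compound 1 by propyl in place of phenyl on an aromatic carbon. Compound 2 gives 12500 nM, level with compound 1 within the scatter.

The step of no change at the digits printed from compound 1 to compound 4 (within the scatter) is expected to be none beyond the scatter, since compound 2 gives 12500 nM. Compound 4 is therefore estimated at 12500 nM, with a range from 5000 nM to 50000 nM.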

Compound 4, minimum cytotoxic concentration: 50000 nM
Beside the measured number, compound 4's estimate is 4.0-fold (0.60 log units) below it; the measured number falls inside the stated range.
By their numbers in this assay, from the lowest: compounds 1 and 2 (each within the scatter of the next); then compound 4. At a limit, above all of these: compound 3.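

Notes on the position on the five-membered aromatic ring with 1 sulfur, next to the ring atom that bears a large group: in this assay, this is the first place in the series where a single structural change can be sized, and propyl in place of phenyl gives a 4.0-fold higher number from compound 1 to compound 4 (0.60 log units; beyond the scatter). The step is modest but beyond the scatter, so this position is not indifferent to the group it carries, and losing the six-membered aromatic ring does not lower the tolerated concentration in this pair. Nothing at hand gives a cause for this step.

A single pair cannot separate the loss of the aromatic ring from the drop in heavy atoms, as the two changes arrive together in propyl in place of phenyl. A cyclohexyl group at this position would keep a six-membered ring without the aromatic character, while an ethyl or pentyl chain would test whether the number in this assay tracks chain length at all.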